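The source may report more compounds than this note shows. Statements on the series, on what has been measured and on what is new or still open speak of the compounds shown alone.

Compound 1 `CC(=O)Oc1cccc(/C=C/c2nc3ccccc3c(=O)[nH]2)c1`: 15300 nM
Compound 2 `COc1ccccc1/C=C/c1nc(Nc2ccccc2Cl)c2ccccc2n1`: > 25000 nM

Both compounds were tested in a functional assay on HCT-116 cells (Homo sapiens) for antiproliferative activity, with a stated time of 72 h; on this read-out higher numbers stand for weaker inhibition and lower numbers for stronger inhibition. Compound 2 gives no number there, only a limit of > 25000 nM. Compound 3 `COc1ccccc1/C=C/c1nc(Nc2cccc(O)c2)c2ccccc2n1` is the next to be measured, and the change leading to it is 3-hydroxyphenyl in place of 2-chlorophenyl on a nitrogen on an aromatic ring. Within the data shown here, no step between measured compounds guides its size, so the expectation is loose. A modest move towards stronger inhibition is expected, and the estimate is an at least 2.0-fold lower number from compound 2 to compound 3 (0.31 log units; beyond the scatter). Among the measured compounds shown here, the only measured number is that of compound 1, at 15300 nM, and the expectation stays near it. For compound 3 the estimated value in this assay is 12000 nM, with an expected range from 3000 nM to 25000 nM.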

Compound 3, half-maximal inhibitory concentration: 21700 nM
Compound 3: the middle estimate sits 1.8-fold (0.26 log units) below what was measured, within the range that was stated.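

In this assay, placing 3-hydroxyphenyl on the nitrogen gives compound 3 a measured value of 21700 nM on the shared core. The change from 2-chlorophenyl reads only as an at least 1.1-fold lower number from compound 2 to compound 3 (0.06 log units; that floor lies within the scatter). The true size of this step remains unknown because compound 2 has only a limit, not a number: the limit of > 25000 nM in this assay, at which 1 of the 3 values shown sits.

The compounds shown do not separate the loss of the chlorine from the gain of the hydroxyl. They also leave open how an amine or a carboxylic acid in place of that hydroxyl would read in this assay.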